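Quinazoline thioethers: arylamino for piperidinyl at the aminated carbon

The source may hold more compounds than are shown below. What is called first, only, known or untested is meant among the compounds shown, and "the series" means these compounds.

Measured compounds in a functional assay on MDA-MB-231 cells (Homo sapiens) for cytotoxicity, read by MTT assay, with a stated time of 72 h; a higher number here means a weaker inhibitor, a lower number a stronger inhibitor:
compound 1 `CCCCCCNc1nc(SCc2ccc(C(F)(F)F)cc2)nc2ccccc12`, 20200 nM
compound 2 `FC(F)(F)c1ccc(CSc2nc(N3CCCCC3)c3ccccc3n2)cc1`, 28400 nM
compound 3 `Cc1ccccc1Nc1nc(SCc2ccc(C(F)(F)F)cc2)nc2ccccc12`, 27100 nM

All three values sit close together. Among the compounds with values here, compound 2 is nearest to compound 3 (a 1.0-fold lower number from compound 2 to compound 3 (0.02 log units; within the scatter)) and furthest from compound 1 (a 1.4-fold higher number from compound 1 to compound 2 (0.15 log units; within the scatter)), both gaps inside the scatter, so no compound can be set apart from the others.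

Compound 4 `FC(F)(F)c1ccc(CSc2nc(Nc3ccc(Cl)cc3)c3ccccc3n2)cc1` differs from compound 2 by (4-chlorophenyl)amino in place of piperidin-1-yl on an aromatic carbon. Within the data shown here, the one measured step that bears on this, exchanging the same piperidin-1-yl for an arylamino group, is a 1.0-fold lower number from compound 2 to compound 3 (0.02 log units; within the scatter); the exchange of hexyl for aryl on the nitrogen, a 1.3-fold higher number from compound 1 to compound 3 (0.13 log units; within the scatter), was also flat. No step beyond the scatter is therefore expected in this assay: compound 4 is estimated at 25000 nM, range 12000 nM to 52000 nM, a step of a 1.1-fold lower number from compound 2 to compound 4 (0.06 log units; within the scatter).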

Compound 4, half-maximal inhibitory concentration: 15100 nM
The estimate for compound 4 lay 1.7-fold (0.22 log units) above the measured number, and the stated range covers the measured number.
By their numbers in this assay, from the lowest: compounds 4, 1, 3 and 2 (each within the scatter of the next).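

In this assay, (4-chlorophenyl)amino in place of piperidin-1-yl gives a 1.9-fold lower number from compound 2 to compound 4 (0.27 log units; within the scatter), while the exchanges on the nitrogen give a 1.8-fold lower number from compound 3 to compound 4 (0.25 log units; within the scatter) and a 1.3-fold lower number from compound 1 to compound 4 (0.13 log units; within the scatter). Adding a chlorine-bearing aryl group therefore does not set compound 4 apart from compound 1, compound 2 or compound 3, and this position still shows no preference among the four groups. No measurement at hand bears on this flat response.

As far as these compounds go, whether a carboxylic acid on the phenyl ring or a chain longer than hexyl would give a step beyond the scatter stays open. From the compounds shown here alone, whether the flat response extends to other cell lines also stays open.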